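The source may report more compounds than this note shows. Statements on the series, on what has been measured and on what is new or still open speak of the compounds shown alone.

Compound 1 `NCCNc1cc(N2CCN(S(=O)(=O)c3ccccc3)CC2)nc2ccccc12`: 20500 nM
Compound 2 `CC(C)CC(=O)N1CCN(c2cc(NCCN)c3ccccc3n2)CC1`: > 100000 nM, a limit of the assay

In an ADME assay on HEp-2 cells (Homo sapiens) for cytotoxicity, read by CCK-8 assay, with a stated time of 6 days (on this read-out lower numbers stand for higher toxicity in this test and higher numbers for lower toxicity in this test), compound 1 gives 20500 nM. For compound 2 the read-out stops at > 100000 nM, which is a limit of the assay and not a number, so compound 2 stands only within a range; this is the case described by the limit of > 100000 nM in this assay, at which 1 of the 2 values shown sits. Among the measured compounds shown here, the one measured step, an at least 4.8-fold higher number from compound 1 to compound 2 (0.68 log units; beyond the scatter), was therefore known only as a lower bound. Compound 3 `NCCNc1cc(N2CCN(c3ccccc3Cl)CC2)nc2ccccc12` differs from compound 2 by 2-chlorophenyl in place of isobutylcarbonyl on an amine nitrogen in a ring. The measured step bears on it only in part: it shows that a flat aromatic group on the ring nitrogen went with a lower number than the isobutylcarbonyl of compound 2. Since 2-chlorophenyl is again an aromatic ring on the same nitrogen, a lower number than that of compound 2 is expected for compound 3, as a step of an at least 2.8-fold lower number from compound 2 to compound 3 (0.45 log units; beyond the scatter). Compound 3 is therefore estimated at 35000 nM, between 12000 nM and 100000 nM.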

Compound 3, half-maximal cytotoxic concentration: 20800 nM
Compound 3: middle estimate off by 1.7-fold (0.23 log units), on the high side; the range from low to high includes it.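

Replacing phenylsulfonyl with 2-chlorophenyl on the amine nitrogen in the ring gives a 1.0-fold higher number from compound 1 to compound 3 (0.01 log units; within the scatter) in this assay, so the sulfonyl link can be lost without any measurable change so long as an aromatic ring stays on this nitrogen. Replacing isobutylcarbonyl with 2-chlorophenyl gives an at least 4.8-fold lower number from compound 2 to compound 3 (0.68 log units; beyond the scatter), which sets compound 2 apart from the two compounds that carry an aromatic ring here. The size of that gap remains a bound, as compound 2 is known only as a limit of the assay and not as a number: the limit of > 100000 nM in this assay, at which 1 of the 3 values shown sits.

As far as these compounds go, whether a benzoyl group, with its aromatic ring on a carbonyl, would read like compound 3 or like compound 2 stays open. The compounds shown also leave open what the chlorine contributes, since none carries an unsubstituted phenyl directly on this nitrogen.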